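A few compounds are considered here, and "the series" means these few. Any claim that something is new, unique, unknown or untested is made for them only; others in the source may bear on it.

Measured so far in a functional assay on A549 cells (Homo sapiens) for cytotoxicity, read by MTT assay, with a stated time of 72 h; a lower number here means a stronger inhibitor, a higher number a weaker inhibitor:

compound 1 `O=C1CC(c2c(-c3ccc[nH]3)[nH]c3ccccc23)C(=O)N1`: in this assay compound 1 gives 8000 nM.
compound 2 `Cc1ccc2[nH]c3c4cn[nH]c4c4c(c3c2c1)C(=O)NC4=O`: in this assay compound 2 gives > 100000 nM, a limit of the assay and not a number.
compound 3 `O=C1NC(=O)c2c1c1[nH]ncc1c1[nH]c3ccccc3c21`: in this assay compound 3 gives > 100000 nM, also a limit and not a number.

Among the measured compounds shown here, compound 1 thus carries the only number in the set; the other two values sit at the limit of > 100000 nM in this assay, at which 2 of the 3 values shown sit. The step that the two limits leave unreadable from compound 3 to compound 2 cannot be read, because both ends are limits. That step is methyl in place of hydrogen on an aromatic carbon.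

Compound 4 `Cc1ccc2[nH]c(-c3ccc[nH]3)c(C3CC(=O)NC3=O)c2c1` is not yet measured. It differs from compound 1 by methyl in place of hydrogen on an aromatic carbon. For the measured compounds named here, this is the same kind of change as the one from compound 3 to compound 2, though not the same: there the six-membered ring is part of a fused or bridged system of five rings, here of two rings. How the core of compound 1 differs from the core of compound 3 is not broken down here.

Since the measured step gives no readable size, the expectation for compound 4 rests on compound 1 alone, with its value of 8000 nM, and a step within the usual scatter is expected, no change at the digits printed from compound 1 to compound 4 (within the scatter). Compound 4 is estimated at 8000 nM, between 3000 nM and 25000 nM.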

Compound 4, half-maximal inhibitory concentration: 20000 nM
Compound 4: the middle estimate sits 2.5-fold (0.40 log units) below what was measured, within the range that was stated.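

In this assay, methyl in place of hydrogen on an aromatic carbon of the core of compound 1 gives a 2.5-fold higher number from compound 1 to compound 4 (0.40 log units; beyond the scatter), so on this core the change costs a modest amount of potency. The same change on the core of compound 3 cannot be read, as both ends of that step are limits of the assay and not numbers: the limit of > 100000 nM in this assay, at which 2 of the 4 values shown sit. The series therefore holds a single readable instance of this change, which shows its direction and size on one core only and does not show whether either would carry over to the other core.

Open, on these data alone, is whether an amine, a methoxy group or a longer chain such as propyl on the same aromatic carbon would shift the value in the same direction as methyl. Also open is whether the step would hold on the other carbons of that six-membered ring, as the compounds shown carry methyl in one place only.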